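Benzamide swap in a thiazole series: second occurrence

This account rests on a few compounds, and the source may have more. Where it says the series, first, only, none or still open, it means among the compounds named here.

Measured so far, all in a functional assay on Ramos cells (Homo sapiens) for antiproliferative activity, read by CCK-8 assay, with a stated time of 72 h, tested at 40 uM; a lower number here means less inhibition, a higher number more inhibition at the concentration tested (going by the name of the read-out):
Compound 1 `CCOC(=O)c1sc(-c2cccc(NC(=O)c3ccccc3F)c2)nc1Nc1ccc(N2CCN(C)CC2)cc1`: compound 1 gives 96.4%.
Compound 2 `CCOC(=O)c1sc(-c2cccc(NC(=O)c3ccc(Cl)cc3)c2)nc1Nc1ccc(N2CCN(C)CC2)cc1`: compound 2 gives 46.9%.
Compound 3 `CN1CCN(c2ccc(Nc3nc(-c4cccc(NC(=O)c5ccccc5F)c4)sc3C(N)=O)cc2)CC1`: compound 3 gives 95.5%.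

Two single changes connect these. From compound 1 to compound 2 the change is 4-chlorophenyl in place of 2-fluorophenyl on a carbonyl carbon, and it gives a number 49.5 percentage points lower from compound 1 to compound 2 (beyond the scatter). From compound 1 to compound 3 the cores differ by amino in place of ethoxy on a carbonyl carbon; this gives a number 0.9 percentage points lower from compound 1 to compound 3 (within the scatter), so compound 1 and compound 3 are not told apart in this assay.

Compound 4 `CN1CCN(c2ccc(Nc3nc(-c4cccc(NC(=O)c5ccc(Cl)cc5)c4)sc3C(N)=O)cc2)CC1` is not yet measured. It stands to compound 3 as compound 2 stands to compound 1: the change is 4-chlorophenyl in place of 2-fluorophenyl on a carbonyl carbon, at a place described in the same words, so it is the same change. Going by the values given here, the expectation rests on the one earlier instance, a number 49.5 percentage points lower from compound 1 to compound 2 (beyond the scatter), and on compound 3 matching compound 1 within scatter in a number 0.9 percentage points lower from compound 1 to compound 3 (within the scatter). Compound 4 is expected to show a number 49.5 percentage points lower from compound 3 to compound 4 (beyond the scatter), close to the earlier step. Compound 4 is estimated at 46% in this assay. For compound 4 the expected range runs from 28% to 64%.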

Compound 4, a percentage reported as inhibition, at one concentration (the size of the read-out at that concentration, not a potency): 99%
Beside the measured number, compound 4's estimate is 53 percentage points below it; the measured number lies above the stated range.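

On the core of compound 3 the benzamide change gives a number 3.5 percentage points higher from compound 3 to compound 4 (within the scatter), so in this assay 4-chlorophenyl in place of 2-fluorophenyl does not carry over from the core of compound 1: the same change on two cores in this assay, a number 49.5 percentage points lower (beyond the scatter) from compound 1 to compound 2 and a number 3.5 percentage points higher (within the scatter) from compound 3 to compound 4, 53 percentage points apart, beyond the scatter of two such steps

Read the other way, amino in place of ethoxy gives a number 52.1 percentage points higher from compound 2 to compound 4 (beyond the scatter) with the 4-chlorophenyl amide, while with the 2-fluorophenyl amide it made no difference beyond the scatter: the same change on two cores in this assay, a number 0.9 percentage points lower (within the scatter) from compound 1 to compound 3 and a number 52.1 percentage points higher (beyond the scatter) from compound 2 to compound 4, 53 percentage points apart, beyond the scatter of two such steps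

The two changes therefore do not add independently in these four compounds, with compound 2 the only one that stands apart, but this does not show why, and a read-out at one concentration does not show that compound 3 and compound 4 are equal in potency.

Open, on these data alone, is whether the drop belongs to compound 2 alone or recurs with other amides, such as a plain phenyl on the same carbonyl carbon. Also open, as far as these compounds go, is how a methylamino group or a hydroxy group in place of ethoxy would behave with the 4-chlorophenyl amide.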